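Swapping the urea aryl group in a thienopyrimidine series

The compounds below may be only part of what the source reports. "The series", "measured", "known", "first", "only" and "open" are said of these compounds alone.

Measured compounds:
- compound 1, `CN(C)CCCNc1nc(-c2ccc(NC(=O)Nc3ccc(Cl)cc3Cl)cc2)nc2c(Cl)c(Cl)sc12`: 2560 nM
- compound 2, `CN(C)CCNc1nc(-c2ccc(NC(=O)Nc3ccc(F)cc3)cc2)nc2ccsc12`: 330 nM
- compound 3, `CN(C)CCNc1nc(-c2ccc(NC(=O)Nc3ccc(F)cc3)cc2)nc2c(Cl)c(Cl)sc12`: 1350 nM

All three compounds were tested in a functional assay on MKN-45 cells (Homo sapiens) for cytotoxicity, read by MTT assay, with a stated time of 72 h; a lower number here means a stronger inhibitor, a higher number a weaker inhibitor. Among them, compound 2 gives the lowest number, 330 nM, and its separation from compound 3 and from compound 1 lies beyond the usual scatter, so it is the strongest inhibitor of the three on these data. Compound 3 gives 1350 nM and compound 1 gives 2560 nM; these two values lie close together, and their two structures differ in more than one place, so nothing further is drawn from that pair.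

The next compound, compound 4, `CN(C)CCNc1nc(-c2ccc(NC(=O)Nc3ccc(Cl)cc3Cl)cc2)nc2ccsc12`, is not yet measured. It is compound 2 with one change: 2,4-dichlorophenyl in place of 4-fluorophenyl on an amide-type nitrogen. The rest of the molecule, including the shared core and the side chain on the amine, stays as in compound 2.

Within the data shown here, no measured pair shows this exact change on its own. Compound 1 already carries the 2,4-dichlorophenyl group, but on a different core and a longer chain, so it only sets a loose reference. The expectation for the step from compound 2 to compound 4 is a modest move toward a higher number, a 1.7-fold higher number from compound 2 to compound 4 (0.22 log units; within the scatter), though a result within the scatter of compound 2 would not be surprising. Compound 4 is therefore estimated at 550 nM, with a range from 150 nM to 2000 nM.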

Compound 4, half-maximal inhibitory concentration: 2360 nM
Compound 4: the middle estimate sits 4.3-fold (0.63 log units) below what was measured; the whole stated range lies below it.
By their numbers in this assay, from the lowest: compound 2; then compounds 3, 4 and 1 (each within the scatter of the next).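

In this assay, with the shared core and the side chain on the amine held fixed, putting 2,4-dichlorophenyl in place of 4-fluorophenyl on an amide-type nitrogen gives a 7.2-fold higher number from compound 2 to compound 4 (0.85 log units; beyond the scatter), a clear loss of inhibitory strength. The earlier compounds shown here could not show this, since none of them formed a pair differing only in this group, and compound 1 changed the core and the chain as well. This position is therefore sensitive to the choice of aryl group, at least on this core and with this side chain, but nothing measured here explains why the change has so large an effect.

The step swaps the whole aryl group at once, so it cannot separate the loss of the fluorine from the gain of the two chlorines; phenyl without any substituent, 4-chlorophenyl and 2-chlorophenyl would each help to divide the change into smaller parts. From the compounds shown here alone, it also remains open whether the same swap would have an effect of similar size on the core of compound 3, which carries two chlorines, or with the longer chain of compound 1.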